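Swapping chloro for fluoro on the benzyl ring

A few compounds are considered here, and "the series" means these few. Any claim that something is new, unique, unknown or untested is made for them only; others in the source may bear on it.

Compound 1 `O=C(/C(=C\c1ccc(O)cc1)SCc1ccc(Cl)cc1)c1ccc(Br)cc1`: 10000 nM
Compound 2 `COc1ccc(/C=C(/SCc2ccc(Cl)cc2)C(=O)c2ccc(Br)cc2)cc1`: 10000 nM
Compound 3 `O=C(/C(=C\c1ccc(Cl)cc1)SCc1ccc(Cl)cc1)c1ccc(Br)cc1`: 10000 nM

All three were tested in a functional assay on DU-145 cells (Homo sapiens) for inhibition, read by trypan blue exclusion, with a stated time of 96 h; a higher number here means a weaker inhibitor of growth, a lower number a stronger inhibitor of growth. Compound 2 stands level with compound 1 and compound 3: the steps of no change at the digits printed from compound 1 to compound 2 (within the scatter), no change at the digits printed from compound 2 to compound 3 (within the scatter) and no change at the digits printed from compound 1 to compound 3 (within the scatter) all stay within the scatter, even though each alters the group on the other aromatic ring. Compound 4 `COc1ccc(/C=C(/SCc2ccc(F)cc2)C(=O)c2ccc(Br)cc2)cc1` differs from compound 2 in a single place: fluoro in place of chloro on an aromatic carbon. Within the data shown here, none of the measured steps touches this ring, so there is nothing in the data that speaks for a shift in either direction. Compound 4 is therefore expected to stay at the same level in this assay, a step of no change at the digits printed from compound 2 to compound 4 (within the scatter), with an estimate of 10000 nM and a range from 4000 nM to 25000 nM.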

Compound 4, concentration for 50% growth inhibition: 50000 nM
Estimate against measurement, compound 4: 5.0-fold (0.70 log units) below; measured number above the stated range.
By their numbers in this assay, from the lowest: compounds 1, 2 and 3 (each within the scatter of the next); then compound 4.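

The benzyl ring is not a silent part of these molecules in this assay: fluoro in place of chloro gives a 5.0-fold higher number from compound 2 to compound 4 (0.70 log units; beyond the scatter), whereas swaps on the other aromatic ring left compound 1, compound 2 and compound 3 level. So one halogen swap at this place is enough to weaken growth inhibition, though this rests on a single pair. Nothing available here explains the shift.

From the compounds shown here alone, it remains open how a bromo, methyl or amine group on this same aromatic carbon would compare. Whether fluoro has the same effect with a hydroxy or chloro group on the other ring is also unknown.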